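A Methylsulfonyl Step Repeated on a Second Core

The source may hold more compounds than are shown below. What is called first, only, known or untested is meant among the compounds shown, and "the series" means these compounds.

Measured so far:
compound 1 `C[S+]([O-])c1ccc(CSc2nc(-c3ccc(Cl)cc3)c(-c3ccncc3)[nH]2)cc1`: 320 nM
compound 2 `CS(=O)(=O)c1ccc(CSc2nc(-c3ccc(Cl)cc3)c(-c3ccncc3)[nH]2)cc1`: 320 nM
compound 3 `C[S+]([O-])c1ccc(CSc2nc(-c3ccccc3)c(-c3ccncc3)[nH]2)cc1`: 840 nM

In a functional assay (Homo sapiens) for inhibition (a lower number here means a stronger inhibitor, a higher number a weaker inhibitor), compound 1 gives 320 nM. Compound 2 differs from compound 1 by a group of 4 heavy atoms (1 carbon, 2 oxygen, 1 sulfur; no ring) in place of a group of 3 heavy atoms (1 carbon, 1 oxygen, 1 sulfur; no ring), on an aromatic carbon. In this assay compound 2 gives 320 nM, so no change at the digits printed from compound 1 to compound 2 (within the scatter). Compound 3 differs from compound 1 by hydrogen in place of chloro on an aromatic carbon. In this assay compound 3 gives 840 nM; here a 2.6-fold higher number from compound 1 to compound 3 (0.42 log units; beyond the scatter).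

Compound 4 `CS(=O)(=O)c1ccc(CSc2nc(-c3ccccc3)c(-c3ccncc3)[nH]2)cc1` has the core of compound 3 and differs from it by a group of 4 heavy atoms (1 carbon, 2 oxygen, 1 sulfur; no ring) in place of a group of 3 heavy atoms (1 carbon, 1 oxygen, 1 sulfur; no ring), on an aromatic carbon. The place is the same as for the step from compound 1 to compound 2, so it is the same change. Because no change at the digits printed from compound 1 to compound 2 (within the scatter), the expected step from compound 3 to compound 4 is no change at the digits printed from compound 3 to compound 4 (within the scatter). Compound 4 is therefore estimated at 840 nM, between 420 nM and 1700 nM.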

Compound 4, half-maximal inhibitory concentration: 1700 nM
The estimate for compound 4 lay 2.0-fold (0.31 log units) below the measured number; low and high end bracket the measured number.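

In this assay, methylsulfonyl in place of the group it replaces gave a 2.0-fold higher number from compound 3 to compound 4 (0.31 log units; beyond the scatter), and set beside the earlier step, the two agree within the scatter: the same change on two cores in this assay, no change at the digits printed (within the scatter) from compound 1 to compound 2 and a 2.0-fold higher number (0.31 log units; beyond the scatter) from compound 3 to compound 4, 2.0-fold (0.31 log units) apart, within the scatter of two such steps. Hydrogen in place of chloro gave a 5.3-fold higher number from compound 2 to compound 4 (0.73 log units; beyond the scatter), which also agrees with its earlier step: the same change on two cores in this assay, a 2.6-fold higher number (0.42 log units; beyond the scatter) from compound 1 to compound 3 and a 5.3-fold higher number (0.73 log units; beyond the scatter) from compound 2 to compound 4, 2.0-fold (0.31 log units) apart, within the scatter of two such steps. Both changes therefore carried from one core to the other within the scatter, but this rests on a single pair of steps for each change and does not show that either step holds on other cores in this series, or why.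

The compounds shown leave open whether a carboxylic acid or an amine in place of methylsulfonyl would carry across in the same way. They also leave open how fluoro or methoxy in place of chloro would behave.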